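Aryl ether variation and cytotoxicity in the series

The compounds below may be only part of what the source reports. "The series", "measured", "known", "first", "only" and "open" are said of these compounds alone.

Measured so far:
compound 1 `N#Cc1ccc(Nc2nc(Oc3ccc(Br)cc3)c3ccccc3n2)cc1` gives 215000 nM
compound 2 `N#Cc1ccc(Nc2nc(Oc3ccccc3)c3ccccc3n2)cc1` gives 370000 nM

Two compounds have been run in an ADME assay on MT4 cells (Homo sapiens) for cytotoxicity, read by MTT assay, with a stated time of 4 days; on this read-out lower numbers stand for higher toxicity in this test and higher numbers for lower toxicity in this test. Compound 2 holds the highest of the two numbers; its nearest neighbour is compound 1, and the step of a 1.7-fold higher number from compound 1 to compound 2 (0.24 log units; within the scatter) lies within the scatter, so the two cannot be ordered on this read-out.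

Compound 3 `Cc1cc(C)c(Oc2nc(Nc3ccc(C#N)cc3)nc3ccccc23)c(C)c1` remains to be measured. Against compound 2 the change is 2,4,6-trimethylphenyl in place of phenyl on an oxygen on an aromatic ring. Among the compounds with values here, the one step measured so far concerns a different place, the bromo of compound 1, and was small (a 1.7-fold higher number from compound 1 to compound 2 (0.24 log units; within the scatter)); no step at the aryl ether position itself has been recorded, and no pattern can be claimed for it.

Given that the only change seen in this assay stayed within the scatter, compound 3 is expected to sit close to compound 2, with the step of a 1.5-fold lower number from compound 2 to compound 3 (0.17 log units; within the scatter) estimated and not expected to exceed the scatter. For compound 3 the estimated value in this assay is 250000 nM, with a range from 90000 nM to 600000 nM.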

Compound 3, half-maximal cytotoxic concentration: > 34000 nM
Compound 3: no number, only a limit; the forecaster's own chance of this, stated with the estimate: 25%; the middle value is on the limit's open side.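

In this assay compound 3 gives > 34000 nM, which is a limit and not a number. Within the data shown here, no step from compound 1 or compound 2 to compound 3 can be read from it. The compounds shown leave open whether 2,4,6-trimethylphenyl in place of phenyl on an oxygen on an aromatic ring shifts this read-out at all, and in which direction.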